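Adding an Ethyl Group to the Sulfonamide Nitrogen of Compound 3

A few compounds are considered here, and "the series" means these few. Any claim that something is new, unique, unknown or untested is made for them only; others in the source may bear on it.

Measured compounds:
compound 1 `CCNS(=O)(=O)Cc1noc2ccccc12`: 39 mg/kg
compound 2 `NS(=O)(=O)Cc1noc2ccc(F)cc12`: 15 mg/kg
compound 3 `NS(=O)(=O)Cc1noc2ccc(Cl)cc12`: 14 mg/kg

All three were tested in a functional assay on the whole organism (strain STD-dd) with Mus musculus as the target, in the maximal electroshock model, with a stated time of 2 h; on this read-out lower numbers stand for an effect already at smaller amounts and higher numbers for an effect only at larger amounts of compound. Compound 1 gives 39 mg/kg, compound 2 gives 15 mg/kg, and compound 3 gives 14 mg/kg. Compound 3 therefore carries the lowest number of the three, but its gap to compound 2 lies within the scatter, so the two cannot be ranked; only compound 1 stands clearly apart, with a higher number beyond the scatter.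

Compound 4 `CCNS(=O)(=O)Cc1noc2ccc(Cl)cc12` is not yet measured. It differs from compound 3 by ethyl in place of hydrogen on a sulfonamide nitrogen. Going by the values given here, the one measured step, a 1.1-fold lower number from compound 2 to compound 3 (0.03 log units; within the scatter), concerns a halogen on the aromatic ring and not the sulfonamide nitrogen, so it says little about this change. Among the compounds with values here, compound 1 and compound 3 differ in two places at once, the ethyl on the nitrogen and the chloro on the ring, so their values show only that the ethyl-bearing compound 1 sits higher than compound 3.

On that basis compound 4 is expected to show a higher number than compound 3, with a 2.1-fold higher number from compound 3 to compound 4 (0.33 log units; beyond the scatter) as the estimated step. The estimated value for compound 4 in this assay is 30 mg/kg, with a range from 14 mg/kg to 65 mg/kg.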

Compound 4, dose for half-maximal effect: 21 mg/kg
Compound 4: the middle estimate sits 1.4-fold (0.15 log units) above what was measured, within the range that was stated.
By their numbers in this assay, from the lowest: compounds 3, 2, 4 and 1 (each within the scatter of the next, the first and the last beyond it).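

Going by these compounds alone, compound 3 and compound 4 differ only at the sulfonamide nitrogen, so this pair isolates the effect of ethyl in place of hydrogen for the first time. In this assay, the change gives a 1.5-fold higher number from compound 3 to compound 4 (0.18 log units; within the scatter), which means that the two compounds cannot be told apart and that this position can carry ethyl without a difference beyond the usual variation between repeat measurements. The new compound also isolates the ring change with ethyl held constant, which gives a 1.9-fold lower number from compound 1 to compound 4 (0.27 log units; within the scatter), so this single change does not separate its pair either, and no supporting data are available to explain either step.

The compounds shown carry only hydrogen or ethyl on the sulfonamide nitrogen, so it remains open how a longer chain such as butyl, a cyclopropyl ring or a carboxylic acid would read out at this position. On these data alone, it is also open whether ethyl on this nitrogen would give a similar step with fluoro on the aromatic carbon in place of chloro.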